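Swapping Ethynyl for Thiophen-3-yl on a Shared Nucleoside Core

A few compounds are considered here, and "the series" means these few. Any claim that something is new, unique, unknown or untested is made for them only; others in the source may bear on it.

Compound 3 `C#Cc1cn([C@@H]2O[C@H](CO)[C@@H](O)[C@H]2O)c2nc(C)nc(N)c12` was tested in a functional assay on HCT-116 cells (Homo sapiens), read by MTT assay, with a stated time of 72 h; on this read-out lower numbers stand for stronger inhibition and higher numbers for weaker inhibition. Compound 3 gives > 20000 nM, which is a limit of the assay rather than a number. Compound 1 `Nc1nc(N)c2c(-c3ccsc3)cn([C@@H]3O[C@H](CO)[C@@H](O)[C@H]3O)c2n1` likewise reaches only a limit, > 20000 nM. Compound 2 `C#Cc1cn([C@@H]2O[C@H](CO)[C@@H](O)[C@H]2O)c2ncnc(NC)c12` also gives a limit, > 20000 nM. All three measured compounds therefore sit at the limit of > 20000 nM in this assay, at which 3 of the 3 values shown sit, and compound 3 has no measured neighbour differing from it in one place. Compound 4 `Cc1nc(N)c2c(-c3ccsc3)cn([C@@H]3O[C@H](CO)[C@@H](O)[C@H]3O)c2n1` remains to be measured; it differs from compound 3 by thiophen-3-yl in place of ethynyl on an aromatic carbon. With only limits to build on, the expected step in this assay is none beyond the scatter: a step that the limit leaves unreadable from compound 3 to compound 4. Compound 4 is thus estimated at about 30000 nM, within 10000 nM to 100000 nM, most likely reported again as a limit.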

Compound 4, half-maximal inhibitory concentration: > 20000 nM
Compound 4 gave a limit, no number (the forecaster's own chance of this, stated with the estimate: 85%); the middle value lies beyond the limit too.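

Compound 4 also gives only a limit, so neither its step from compound 3 nor its step from compound 1 can be read: the limit of > 20000 nM in this assay, at which 4 of the 4 values shown sit. The compounds shown leave open whether thiophen-3-yl in place of ethynyl, or methyl in place of amino, changes activity at all.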